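This account rests on a few compounds, and the source may have more. Where it says the series, first, only, none or still open, it means among the compounds named here.

Working notes on the urea series.

Among the measured compounds shown here, compound 2 `O=C(Nc1cccc(F)c1)N[C@H]1CC[C@H](Oc2ccc(F)cc2)CC1` is the weakest of the three measured members: in a functional assay on CRL2813 cells (Homo sapiens) for cytotoxicity, read by sulforhodamine B assay, with a stated time of 5 days (on this read-out lower numbers stand for stronger inhibition and higher numbers for weaker inhibition), compound 2 gives 8300 nM, the highest of the three numbers. Its nearest neighbour is compound 1 `O=C(Nc1cccc(C(F)(F)F)c1)N[C@H]1CC[C@H](Oc2ccc(Cl)cc2)CC1`, which in this assay gives 2000 nM; the most distant is compound 3 `O=C(Nc1cccc(C(F)(F)F)c1)N[C@H]1CC[C@H](Oc2ccccc2C(F)(F)F)CC1`, which in this assay gives 1400 nM. Compound 1 and compound 2 differ in two places at once, so their values are only compared as they stand, not as a single step. For the measured compounds named here, the only single-point step measured, a 1.4-fold lower number from compound 1 to compound 3 (0.15 log units; within the scatter), concerns the group on the oxygen on the saturated carbon and therefore does not bear on the change now in question.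

Compound 4 `CSc1cccc(NC(=O)N[C@H]2CC[C@H](Oc3ccc(F)cc3)CC2)c1` differs from compound 2 by methylsulfanyl in place of fluoro on an aromatic carbon. Going by the values given here, no measured step touches the group on the urea aryl ring, so no direct anchor exists; the only guidance is that compound 2, carrying fluoro here, sits at the top of the range while the trifluoromethyl-bearing compound 1 and compound 3 sit lower. On that basis a modest move toward lower numbers is expected in this assay, without confidence that it clears the scatter. Compound 4 is therefore estimated at 4500 nM, within 1500 nM to 13000 nM, meaning an expected step of a 1.8-fold lower number from compound 2 to compound 4 (0.27 log units; within the scatter).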

Compound 4, half-maximal inhibitory concentration: 11100 nM
Beside the measured number, compound 4's estimate is 2.5-fold (0.39 log units) below it, within the range that was stated.
By their numbers in this assay, from the lowest: compounds 3 and 1 (each within the scatter of the next); then compounds 2 and 4 (each within the scatter of the next).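

In this assay, among the compounds shown here, the step of a 1.3-fold higher number from compound 2 to compound 4 (0.13 log units; within the scatter) is the only reading so far of a single change on the urea aryl ring. It shows that methylsulfanyl in place of fluoro, on an aromatic carbon meta to a large group, leaves the two compounds indistinguishable on this read-out, even though the entering group brings one more heavy atom and a hydrogen-bond acceptor by the count. Both single-place steps now in hand, this one and the step of a 1.4-fold lower number from compound 1 to compound 3 (0.15 log units; within the scatter) on the group on the oxygen, therefore lie within the scatter, and nothing available explains the result or gives a measured property for either group.

For the compounds shown here, it remains open whether trifluoromethyl at this place differs from fluoro or methylsulfanyl when it is the only change, since compound 1 and compound 2 differ in two places at once. Also open, as far as these compounds go, is whether a group of another kind here, such as an amine, a carboxylic acid or a longer chain, would give a step beyond the scatter.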